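Benzyl to hydrogen on an oxygen next to a carbonyl

The source may hold more compounds than are shown below. What is called first, only, known or untested is meant among the compounds shown, and "the series" means these compounds.

Measured compounds:
Compound 1, `Cc1cn([C@@H]2O[C@H](CO[Si](C)(C)C(C)(C)C)[C@@]3(OS(=O)(=O)C=C3NCCC(=O)OCc3ccccc3)[C@H]2O[Si](C)(C)C(C)(C)C)c(=O)n(C)c1=O`: in a functional assay on HEL cells (Homo sapiens) for cytotoxicity, read by microscopy (on this read-out lower numbers stand for higher toxicity in this test and higher numbers for lower toxicity in this test), compound 1 gives >= 400000 nM, which is a limit of the assay and not a number.
Compound 2, `COC(=O)C(=O)CNC1=CS(=O)(=O)O[C@@]12[C@@H](CO[Si](C)(C)C(C)(C)C)O[C@@H](n1cc(C)c(=O)n(C)c1=O)[C@@H]2O[Si](C)(C)C(C)(C)C`: in this assay compound 2 gives > 400000 nM, also a limit.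
Compound 3, `Cc1cn([C@@H]2O[C@H](CO[Si](C)(C)C(C)(C)C)[C@@]3(OS(=O)(=O)C=C3NCCC(N)=O)[C@H]2O[Si](C)(C)C(C)(C)C)c(=O)n(C)c1=O`: in this assay compound 3 gives >= 80000 nM, again a limit.

Compound 1 thus stands only at a limit, and the two further values are limits as well (the limit of > 400000 nM in this assay, at which 1 of the 3 values shown sits, (the limit of >= 400000 nM in this assay, at which 1 of the 3 values shown sits), (the limit of >= 80000 nM in this assay, at which 1 of the 3 values shown sits)). The three measured steps are all unreadable: a step that the two limits leave unreadable from compound 1 to compound 2, a step that the two limits leave unreadable from compound 1 to compound 3, a step that the two limits leave unreadable from compound 2 to compound 3.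

Compound 4, `Cc1cn([C@@H]2O[C@H](CO[Si](C)(C)C(C)(C)C)[C@@]3(OS(=O)(=O)C=C3NCCC(=O)O)[C@H]2O[Si](C)(C)C(C)(C)C)c(=O)n(C)c1=O`, differs from compound 1 by hydrogen in place of benzyl on an oxygen next to a carbonyl group; the same difference cut one bond further out reads benzyloxycarbonyl to carboxy. Among the measured compounds shown here, none of the measured steps bears readably on this change; each of them sits between limits, so their sizes are not known. For the measured compounds named here, no step in this assay beyond the scatter can therefore be predicted in either direction, and the expectation is that compound 4 will also end at a limit rather than a number. Compound 4 is estimated at 400000 nM, with a range of 100000 nM to 800000 nM. The step expected in this assay is a number no higher from compound 1 to compound 4 (the limit leaves the size open), estimated to lie within the scatter.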

Compound 4, minimum cytotoxic concentration: 80000 nM
Estimate against measurement, compound 4: 5.0-fold (0.70 log units) above; the measured number lies below the stated range.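

In this assay, among the compounds shown here, compound 4 gives 80000 nM, the only actual number in this set. Hydrogen in place of benzyl on an oxygen next to a carbonyl group gives an at least 5.0-fold lower number from compound 1 to compound 4 (0.69 log units; beyond the scatter), and carboxymethyl in place of (methoxycarbonyl)carbonyl gives an at least 5.0-fold lower number from compound 2 to compound 4 (0.69 log units; beyond the scatter), so of these two comparisons neither the benzyl ester nor the methyl keto ester reaches the level of the free carboxy compound. Compound 3 gives >= 80000 nM, which is a limit. Hydroxy in place of amino on a carbonyl carbon gives a number no higher from compound 3 to compound 4 (the limit leaves the size open). The steps among compound 1, compound 2 and compound 3 cannot be read: the limit of >= 80000 nM in this assay, at which 1 of the 4 values shown sits.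

The compounds shown leave open whether the lower number belongs to the carboxy group itself or would also appear with a primary amine or a tetrazole at the chain end. On these data alone, how a longer chain ending in carboxy would read, and what underlies the step, also remains open.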